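Series notes: amine substituent change from compound 2 to compound 4

A few compounds are considered here, and "the series" means these few. Any claim that something is new, unique, unknown or untested is made for them only; others in the source may bear on it.

Measured so far in an assay on HEK293 cells for displacement of a labelled ligand from growth hormone secretagogue receptor type 1 (Homo sapiens), with a stated time of 60 min; a lower number here means a stronger inhibitor, a higher number a weaker inhibitor:
compound 1 `COc1cccc(-n2cc3nc(-c4cccnc4C)n(C[C@H]4CCCN(CC5CCCCC5)C4)c(=O)c3n2)c1`: 200 nM
compound 2 `CCO[C@@H](C)CN1CCC[C@H](Cn2c(-c3cccnc3C)nc3cn(-c4cccc(OC)c4)nc3c2=O)C1`: 5 nM
compound 3 `Cc1ncccc1-c1nc2cn(-c3ccccc3)nc2c(=O)n1C[C@H]1CCCN(C[C@H]2CCCO2)C1`: 190 nM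

Compound 2 holds the lowest number of the three in this assay; compound 3 and compound 1 both sit above it by gaps beyond the scatter. Compound 4 `COc1cccc(-n2cc3nc(-c4cccnc4C)n(C[C@H]4CCCN(CC5CCCC5)C4)c(=O)c3n2)c1` differs from compound 2 by cyclopentyl in place of 1-ethoxyethyl on a saturated chain carbon bound to an amine nitrogen in a ring. Going by the values given here, the only step that bears on this is a 40-fold lower number from compound 1 to compound 2 (1.60 log units; beyond the scatter), in which 1-ethoxyethyl replaced cyclohexyl at the same place. Compound 4 puts cyclopentyl, a closely related carbon ring, back into that place, so a large step upward is expected, roughly undoing that earlier gain. Compound 4 is therefore estimated at 150 nM, with a range of 40 nM to 500 nM, an expected step of a 30-fold higher number from compound 2 to compound 4 (1.48 log units; beyond the scatter).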

Compound 4, half-maximal inhibitory concentration: 12 nM
Estimate against measurement, compound 4: 13-fold (1.10 log units) above; the whole stated range lies above it.
By their numbers in this assay, from the lowest: compound 2; then compound 4; then compounds 3 and 1 (each within the scatter of the next).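

Notes on the amine substituent, read in this assay: with cyclopentyl in place of 1-ethoxyethyl, the step of a 2.4-fold higher number from compound 2 to compound 4 (0.38 log units; beyond the scatter) is only modest, so a low number at this place does not require an open chain or the ether oxygen. With cyclopentyl in place of cyclohexyl, the step of a 17-fold lower number from compound 1 to compound 4 (1.22 log units; beyond the scatter) is large, so among these compounds the size of the carbon ring on the chain carbon matters strongly.

From the compounds shown here alone, whether cyclobutyl or a longer chain would follow cyclopentyl remains open. Nothing here gives a measured reason for the gap between the two carbon rings.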